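The compounds below may be only part of what the source reports. "The series", "measured", "known", "first", "only" and "open" are said of these compounds alone.

Among the compounds with values here, compound 1, with the structure `COc1cc(NC(C)CCCNC(=O)Nc2ccc(O)cc2)c2ncccc2c1`, is one of two compounds measured so far in a functional assay on HeLa cells (Homo sapiens) for inhibition, read by MTT assay, with a stated time of 72 h; a higher number here means a weaker inhibitor, a lower number a stronger inhibitor. In this assay compound 1 gives 70000 nM, the higher of the two numbers. Within the data shown here, its only comparison partner is compound 2, `COc1cc(NC(C)CCCNC(=O)Nc2cc(C(F)(F)F)cc(C(F)(F)F)c2)c2ncccc2c1`, which in this assay gives 3100 nM; the gap between the two lies beyond the usual scatter of repeated measurements, so compound 2 is the stronger inhibitor of the pair.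

The next compound, compound 3, has the structure `COc1cc(NC(C)CCCNC(=O)Nc2ccc(Cl)cc2)c2ncccc2c1`. It differs from compound 1 in one place: chloro in place of hydroxy on an aromatic carbon. Among the measured compounds shown here, no measured pair shows exactly this exchange, so its effect has to be guessed. Compound 2, which also carries a different group on that same ring, gives the lower number 3100 nM, and a change toward a non-polar substituent is expected to move compound 3 in the same direction, though by a smaller amount. The step from compound 1 is therefore expected to be a 3.5-fold lower number from compound 1 to compound 3 (0.54 log units; beyond the scatter). Compound 3 is estimated at 20000 nM in this assay, with a plausible range from 6000 nM to 60000 nM.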

Compound 3, half-maximal inhibitory concentration: 18000 nM
Compound 3: the middle estimate sits 1.1-fold (0.05 log units) above what was measured, and the stated range covers the measured number.
By their numbers in this assay, from the lowest: compound 2; then compound 3; then compound 1.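

In this assay, replacing hydroxy with chloro on an aromatic carbon, para to a large group, gives a 3.9-fold lower number from compound 1 to compound 3 (0.59 log units; beyond the scatter). Within the data shown here, this is the first step between compounds that differ in one place, and it shows that this position on the ring responds to what sits there: the hydroxy, with its hydrogen-bond donor and acceptor, leaves, and the chloro, with neither, enters, and the number falls by a modest amount. No measurement at hand bears on the cause of this step, so the change in the number can be described but not explained.

A single exchange cannot show whether the lower number comes from losing the hydroxy or from gaining the chloro, since both happen at once. Compounds with plain hydrogen, a fluoro, a methyl or an amine at this same place would help separate the two, and would show whether the trend from compound 1 to compound 3 extends to other groups or holds only for this one pair.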